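Notes on replacing the 4-chlorophenyl group of compound 1

A few compounds are considered here, and "the series" means these few. Any claim that something is new, unique, unknown or untested is made for them only; others in the source may bear on it.

Within the data shown here, in a functional assay on CCRF-CEM cells (Homo sapiens) for antiproliferative activity, read by cell counting, with a stated time of 2 days (a higher number here means a weaker inhibitor, a lower number a stronger inhibitor), compound 1 `COc1ccc(Nc2nc(N)c(C(=O)c3ccc(Cl)cc3)s2)cc1` gives 19 nM, the only true number so far. Compound 2 `COc1ccc(C(=O)c2sc(Nc3ccc(F)cc3)nc2N)cc1` reads > 10000 nM, which is a limit of this assay and not a number.

Compound 3 `COc1ccc(Nc2nc(N)c(C(=O)c3ccccc3OC)s2)cc1` keeps the core of compound 1 and carries 2-methoxyphenyl in place of 4-chlorophenyl on a carbonyl carbon. Among the measured compounds shown here, no measured pair isolates a change at this place, so the size of the step cannot be read directly from the data. With compound 1 at 19 nM as the only numeric anchor, a weakening in this assay beyond the scatter is expected, though its size is poorly fixed. The estimated step is a 21-fold higher number from compound 1 to compound 3 (1.32 log units; beyond the scatter). For compound 3 the expected value is 400 nM, with an estimated range of 40 nM to 5000 nM.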

Compound 3, half-maximal inhibitory concentration: 17 nM
The estimate for compound 3 lay 24-fold (1.37 log units) above the measured number; the whole stated range lies above it.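

In this assay, among these compounds, 2-methoxyphenyl in place of 4-chlorophenyl on a carbonyl carbon gives a 1.1-fold lower number from compound 1 to compound 3 (0.05 log units; within the scatter), the first step that can be read at this place. The two groups are not told apart here, so with the core of compound 1 unchanged, the chlorine of 4-chlorophenyl is not required to keep the number at the level of compound 1. The same holds for a substituent carried on a different ring carbon, at least for this one pair.

On these data alone, whether this place accepts anything other than a substituted phenyl, such as a simple amine or a carboxylic acid, remains open. Compound 2 reads > 10000 nM, a limit and not a number, and no step to it can be read: the limit of > 10000 nM in this assay, at which 1 of the 3 values shown sits.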